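Swapping One Sulfur Substituent at Low Growth Inhibition

The compounds below may be only part of what the source reports. "The series", "measured", "known", "first", "only" and "open" are said of these compounds alone.

In a functional assay on HeLa cells (Homo sapiens) for inhibition, read by CCK-8 assay, with a stated time of 72 h, tested at 2 uM (a lower number here means less inhibition of growth, a higher number more inhibition of growth at the concentration tested), compound 1 `Cc1cc(C)cc(SCc2ccc(/C=C/C(=O)Nc3ccccc3N)cc2)c1` gives 11.7%. Within the data shown here, compound 2 `CC(C)(C)c1ccc(SCc2ccc(C(=O)Nc3ccccc3N)cc2)cc1`, the only other compound measured so far, gives 9.73%. These two numbers lie within the usual scatter of repeated measurements, so neither compound can be ranked against the other, and both show little inhibition at the concentration tested.

Compound 3 `Nc1ccccc1NC(=O)/C=C/c1ccc(CSCCc2ccccc2)cc1` keeps the core of compound 1 and differs in one place: it carries phenethyl in place of 3,5-dimethylphenyl on a sulfur. No pair of measured compounds shows what an exchange of this kind does to the read-out, so the data offer no direct precedent and no reason to favour a direction. The expectation is therefore no change beyond the scatter, and the estimated step of a number 0.3 percentage points higher from compound 1 to compound 3 (within the scatter) is small. The range is kept wide, and reaches further upward than downward, to allow for this lack of precedent. In this assay, compound 3 is expected at 12%, within an estimated range of 3% to 30%.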

Compound 3, percent growth inhibition at one concentration: 0.19%
For compound 3 the middle estimate is 11.8 percentage points above the measured one; measured number outside the range, below it.
By their numbers in this assay, from the lowest: compounds 3, 2 and 1 (each within the scatter of the next, the first and the last beyond it).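

In this assay, among these compounds, the exchange on the sulfur gives a number 11.5 percentage points lower from compound 1 to compound 3 (beyond the scatter), and this is the first step read at this position. It shows that the read-out responds to what sits on the sulfur, even from a level of inhibition that was already low in compound 1. The two groups match in their count of heavy atoms, in having one six-membered aromatic ring of carbon only, in having no hydrogen-bond donors or acceptors and in carrying no net charge, so these counts alone do not settle the result here, and no measurement at hand explains the drop.

On these data alone, this single pair cannot separate the possible contributions of the two methyl groups on the ring and of the two-carbon chain in phenethyl, so it remains open how a plain phenyl or a benzyl group on the sulfur would read. As far as these compounds go, it is also open whether a longer chain, or a chain ending in an amine or a carboxylic acid, would stay as low as compound 3 or rise above the level of compound 1.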